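Benzyl for cyclopropylmethoxy on a potent antagonist

The source may hold more compounds than are shown below. What is called first, only, known or untested is meant among the compounds shown, and "the series" means these compounds.

Compound 1 `COc1ccccc1N1CCN(CCCNc2ccccc2C(=O)c2ccccc2)CC1`: 31.6 nM
Compound 2 `CCOc1ccccc1N1CCN(CCCNc2ncccc2C(=O)N(C)C)CC1`: 0.501 nM
Compound 3 `CN(C)C(=O)c1cccnc1NCCCN1CCN(c2ccccc2OCC2CC2)CC1`: 0.159 nM

In a functional assay for antagonist activity at Alpha-1A adrenergic receptor (Oryctolagus cuniculus) (on this read-out lower numbers stand for tighter binding and higher numbers for weaker binding), compound 3 gives the lowest number of the three, with compound 2 the nearest and compound 1 far behind. Compound 4 `CN(C)C(=O)c1cccnc1NCCCN1CCN(c2ccccc2Cc2ccccc2)CC1` differs from compound 3 by benzyl in place of cyclopropylmethoxy on an aromatic carbon, sitting on an aromatic carbon of a six-membered aromatic ring of carbon only, ortho to a large group. Among the compounds with values here, the only measured step at this position is a 3.2-fold lower number from compound 2 to compound 3 (0.50 log units; beyond the scatter), which shows that enlarging the group there can move this assay moderately. Within the data shown here, replacing the whole oxygen-linked group with benzyl has no direct precedent, so a step of modest size, most likely toward a higher number, is expected: a 3.8-fold higher number from compound 3 to compound 4 (0.58 log units; beyond the scatter). Compound 4 is estimated at 0.6 nM, within 0.15 nM to 3 nM.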

Compound 4, dissociation constant: 6.31 nM
The estimate for compound 4 lay 11-fold (1.02 log units) below the measured number, and the stated range ends below it.
By their numbers in this assay, from the lowest: compound 3; then compound 2; then compound 4; then compound 1.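

Up to now, the only change at this position was between two oxygen-linked groups, which gave a 3.2-fold lower number from compound 2 to compound 3 (0.50 log units; beyond the scatter) in this assay. Benzyl, which has no oxygen and no hydrogen-bond acceptor, has a much larger effect, with a 40-fold higher number from compound 3 to compound 4 (1.60 log units; beyond the scatter) and a 13-fold higher number from compound 2 to compound 4 (1.10 log units; beyond the scatter) in the same assay. The position therefore responds far more to this replacement than to changing the group on the oxygen.

From the compounds shown here alone, it remains open whether the oxygen or the aromatic ring matters more, which a phenoxy or benzyloxy group could help separate. No measurement here explains the rise.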